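A few compounds are considered here, and "the series" means these few. Any claim that something is new, unique, unknown or untested is made for them only; others in the source may bear on it.

Three measured analogues share one core and differ only in the amine borne on the aromatic carbon. In a functional assay on MCF7 cells (Homo sapiens) for antiproliferative activity, read by MTT assay, with a stated time of 72 h (a lower number here means a stronger inhibitor, a higher number a weaker inhibitor), compound 3 `CCN1CCN(c2cc(C)c3cc(NC(=O)c4ccc(Cl)c(Cl)c4)ccc3n2)CC1` gives 1380 nM; compound 2 `Cc1cc(N2CCN(C(C)C)CC2)nc2ccc(NC(=O)c3ccc(Cl)c(Cl)c3)cc12` gives 1710 nM and compound 1 `Cc1cc(NCCN(C)C)nc2ccc(NC(=O)c3ccc(Cl)c(Cl)c3)cc12` gives 2550 nM. Compound 3 has the lowest number of the three, yet a 1.2-fold lower number from compound 2 to compound 3 (0.09 log units; within the scatter) and a 1.8-fold lower number from compound 1 to compound 3 (0.27 log units; within the scatter) are both within the scatter, as is a 1.5-fold lower number from compound 1 to compound 2 (0.17 log units; within the scatter). Compound 4 `Cc1cc(N2CCCC2)nc2ccc(NC(=O)c3ccc(Cl)c(Cl)c3)cc12` carries pyrrolidin-1-yl in place of 4-ethylpiperazin-1-yl on an aromatic carbon. For the measured compounds named here, none of the measured steps removes a ring nitrogen; the steps that bear on this change are the exchanges of amine at the same place, all within the scatter. For compound 4 a step of a 1.8-fold higher number from compound 3 to compound 4 (0.26 log units; within the scatter) is therefore expected. Compound 4 is estimated at 2500 nM, with a range from 1000 nM to 6500 nM.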

Compound 4, half-maximal inhibitory concentration: 26300 nM
Estimate against measurement, compound 4: 11-fold (1.02 log units) below; the whole stated range lies below it.
By their numbers in this assay, from the lowest: compounds 3, 2 and 1 (each within the scatter of the next); then compound 4.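

In this assay the place next to the ring nitrogen proves sensitive to the amine, which the exchanges among compounds 1, 2 and 3 did not reveal: pyrrolidin-1-yl gives large steps (a 19-fold higher number from compound 3 to compound 4 (1.28 log units; beyond the scatter)), (a 15-fold higher number from compound 2 to compound 4 (1.19 log units; beyond the scatter)) and (a 10-fold higher number from compound 1 to compound 4 (1.01 log units; beyond the scatter)). Only compound 4 lacks a second nitrogen in this group. Nothing available explains the loss. Ring size and nitrogen count change together in this step, so which of them matters stays open. Piperidin-1-yl, with a six-membered ring and a single nitrogen, would separate the two.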